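The source may hold more compounds than are shown below. What is called first, only, known or untested is meant among the compounds shown, and "the series" means these compounds.

Three compounds that share one core and differ in the group on an amide-type nitrogen have been read in an in vitro ADME assay on microsomes from liver (Homo sapiens) for pharmacokinetics, read by LC-MS, with a stated time of 10 min, tested at 1 uM; on this read-out higher numbers stand for fast clearance and lower numbers for slow clearance: compound 1 `CN1C[C@H](C(=O)Nc2ccc(F)cc2)[C@@H](c2ccc(/C=C/C(=O)Nc3ccccc3N)cc2)C1` gives 5 mL/min/kg, compound 2 `COc1ccc(NC(=O)[C@H]2CN(C)C[C@@H]2c2ccc(/C=C/C(=O)Nc3ccccc3N)cc2)cc1` gives 14 mL/min/kg, and compound 3 `CN1C[C@H](C(=O)Nc2cccc(Cl)c2)[C@@H](c2ccc(/C=C/C(=O)Nc3ccccc3N)cc2)C1` gives 7 mL/min/kg. The number for compound 3 thus falls between the other two and within the scatter of both. The steps of a 1.4-fold higher number from compound 1 to compound 3 (0.15 log units; within the scatter) and a 2.0-fold lower number from compound 2 to compound 3 (0.30 log units; within the scatter) show this. Only a 2.8-fold higher number from compound 1 to compound 2 (0.45 log units; beyond the scatter) goes beyond the scatter, and that step brings in methoxy, which compound 4 does not carry. Compound 4 `CN1C[C@H](C(=O)Nc2ccccc2F)[C@@H](c2ccc(/C=C/C(=O)Nc3ccccc3N)cc2)C1` differs from compound 3 in one place: 2-fluorophenyl in place of 3-chlorophenyl on an amide-type nitrogen. For the measured compounds named here, no measured compound carries 2-fluorophenyl, so the closest guide is the change between 4-fluorophenyl and 3-chlorophenyl, seen in a 1.4-fold higher number from compound 1 to compound 3 (0.15 log units; within the scatter). On that evidence, no step beyond the scatter is expected in this assay, and no firm direction can be given. The expected step is a 1.2-fold lower number from compound 3 to compound 4 (0.07 log units; within the scatter). For compound 4 the estimated clearance is 6 mL/min/kg, with an expected range of 3 mL/min/kg to 13 mL/min/kg.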

Compound 4, clearance: 10 mL/min/kg
Compound 4: the middle estimate sits 1.7-fold (0.22 log units) below what was measured, and the stated range covers the measured number.
By their numbers in this assay, from the lowest: compounds 1, 3, 4 and 2 (each within the scatter of the next, the first and the last beyond it).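

In this assay, 2-fluorophenyl on the amide-type nitrogen lies within the scatter of all three earlier groups (a 1.4-fold higher number from compound 3 to compound 4 (0.15 log units; within the scatter); a 1.4-fold lower number from compound 2 to compound 4 (0.15 log units; within the scatter); a 2.0-fold higher number from compound 1 to compound 4 (0.30 log units; within the scatter)). For the compounds shown here, compound 1 and compound 4 differ only in 4-fluorophenyl against 2-fluorophenyl, so this read-out gives the first comparison of two fluorophenyl groups, and it does not separate them. Going by these compounds alone, compound 4 adds no new step beyond the scatter, leaving the gap between compound 1 and compound 2 as the only such step, and nothing measured explains any of these numbers.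

As far as these compounds go, what stays open is whether a group other than a substituted phenyl on this nitrogen, such as a carboxylic acid or a longer alkyl chain, would step beyond the scatter. From the compounds shown here alone, whether 2-methoxyphenyl would differ from 4-methoxyphenyl also remains unknown.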